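Tetrazole in place of oxadiazole at the ketone carbonyl

The compounds below may be only part of what the source reports. "The series", "measured", "known", "first", "only" and "open" are said of these compounds alone.

Compound 1 `O=C(CCCCCCc1ccccc1)c1ncno1` is the reference point of this small series. In an assay on isolated protein for inhibition of liver carboxylesterase 1 (Homo sapiens) (on this read-out higher numbers stand for weaker inhibition and lower numbers for stronger inhibition), compound 1 gives 0.7 nM, the lowest of the two numbers recorded. Among the measured compounds shown here, its nearest neighbour is compound 2 `O=C(CCCCCCc1ccccc1)c1nc(-c2ccccn2)no1`, which in this assay gives 30 nM; the change a 43-fold higher number from compound 1 to compound 2 (1.63 log units; beyond the scatter) is the only single-point step among the measured compounds. Compound 3 `COC(=O)c1cccc(-c2ccc(C(=O)CCCCCCc3ccccc3)nn2)n1` returns no number in this assay but only > 100000 nM, which is a limit of the assay, as noted in the limit of > 100000 nM in this assay, at which 1 of the 3 values shown sits.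

Compound 4 `O=C(CCCCCCc1ccccc1)c1nnn[nH]1` has not yet been measured. It differs from compound 1 by 1H-tetrazol-5-yl in place of 1,2,4-oxadiazol-5-yl on a carbonyl carbon. For the measured compounds named here, none of the measured steps alters the five-membered ring itself: the step from compound 1 to compound 2 adds a pyridin-2-yl group to an aromatic carbon of that ring and leaves it otherwise intact, so it bears on the new change only indirectly, showing that the region around the ring is sensitive. Going by the values given here, with no direct precedent, a modest weakening is expected for compound 4, a 7.1-fold higher number from compound 1 to compound 4 (0.85 log units; beyond the scatter), with wide uncertainty. Compound 4 is therefore estimated to give 5 nM in this assay, between 0.7 nM and 40 nM.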

Compound 4, half-maximal inhibitory concentration: 80 nM
Beside the measured number, compound 4's estimate is 16-fold (1.20 log units) below it, outside the stated range (above it).
By their numbers in this assay, from the lowest: compound 1; then compound 2; then compound 4. At a limit, above all of these: compound 3.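

In this assay, among the compounds shown here, the change of the ring itself gives a 110-fold higher number from compound 1 to compound 4 (2.06 log units; beyond the scatter): this is the first measurement in which 1,2,4-oxadiazol-5-yl is replaced on the carbonyl carbon rather than substituted, and it shows that the position is sensitive to the identity of the ring, even though the entering 1H-tetrazol-5-yl has the same count of heavy atoms and is also a five-membered aromatic ring. Read with a 43-fold higher number from compound 1 to compound 2 (1.63 log units; beyond the scatter), it shows that both single changes made to compound 1 at this ring, one adding a pyridin-2-yl group and one exchanging the ring, raise the number beyond the scatter. The entering ring differs in carrying a hydrogen-bond donor and one more hetero atom, but nothing given here shows which of these differences, if either, accounts for the step.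

The compounds shown leave open how a 1,3,4-oxadiazol-2-yl or a 1-methyltetrazol-5-yl group on the same carbonyl carbon would read in this assay. A methyl group in place of the tetrazole hydrogen would separate the ring's hydrogen from its nitrogen count.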